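The source may hold more compounds than are shown below. What is called first, only, known or untested is meant among the compounds shown, and "the series" means these compounds.

Measured so far:
compound 1 `COc1ccc(OC)c(/C=N/NC(=O)Nc2ccc(Oc3ccnc(-c4nncn4CCN(C)C)c3)c(F)c2)c1` – 1510 nM
compound 2 `CN(C)CCn1cnnc1-c1cc(Oc2ccc(NC(=O)N/N=C/c3c(O)ccc4ccccc34)cc2F)ccn1` – 2020 nM

In a functional assay on MKN-45 cells (Homo sapiens) for cytotoxicity, read by MTT assay, with a stated time of 72 h (a higher number here means a weaker inhibitor, a lower number a stronger inhibitor), compound 1 gives 1510 nM and compound 2 gives 2020 nM. Compound 2 stands at the upper of the two numbers, but the step of a 1.3-fold higher number from compound 1 to compound 2 (0.13 log units; within the scatter) is within the scatter, so the two values cannot be told apart. Compound 3 `COc1ccc(/C=N/NC(=O)Nc2ccc(Oc3ccnc(-c4nncn4CCN(C)C)c3)c(F)c2)cc1O` is the next member. The change from compound 2 is 3-hydroxy-4-methoxyphenyl in place of 2-hydroxynaphthalen-1-yl on a carbon with a double bond to nitrogen. Among the measured compounds shown here, only one measured step touches this position, the exchange of aryl groups from compound 1 to compound 2, and it was within the scatter; no measured step concerns the 3-hydroxy-4-methoxyphenyl group itself. On that basis no step beyond the scatter is expected in this assay, and the step of a 1.2-fold lower number from compound 2 to compound 3 (0.07 log units; within the scatter) is the estimate. Compound 3 is therefore expected to give about 1700 nM, with a range from 700 nM to 4000 nM.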

Compound 3, half-maximal inhibitory concentration: 2510 nM
Compound 3: middle estimate off by 1.5-fold (0.17 log units), on the low side, and the stated range covers the measured number.
By their numbers in this assay, from the lowest: compounds 1, 2 and 3 (each within the scatter of the next).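

In this assay, the steps (a 1.2-fold higher number from compound 2 to compound 3 (0.09 log units; within the scatter) and a 1.7-fold higher number from compound 1 to compound 3 (0.22 log units; within the scatter)) both remain within the scatter, so compound 3 cannot be told apart from either earlier compound. Among the compounds shown here, this extends the picture from the single earlier exchange: the one-ring 3-hydroxy-4-methoxyphenyl group and the two-ring 2-hydroxynaphthalen-1-yl group give no readable difference on the carbon with a double bond to nitrogen, and neither do the two substituted phenyl groups, 3-hydroxy-4-methoxyphenyl and 2,5-dimethoxyphenyl. Nothing available explains this flat result.

All three groups are aryl rings bearing only hydroxy or methoxy substituents. As far as these compounds go, it remains open whether a saturated cyclohexyl group, or an aryl ring carrying a carboxylic acid or a dimethylamino substituent, would give a step beyond the scatter at this position.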